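Chain extension by one carbon: notes on compounds 1 to 4

The source may report more compounds than this note shows. Statements on the series, on what has been measured and on what is new or still open speak of the compounds shown alone.

Measured compounds:
Compound 1, `CCCCc1cc(C(C)=O)c(O)cc1OCCCCC#N`, gives 13% in an assay on isolated protein for binding affinity to leukotriene B4 receptor 1 (Homo sapiens), tested at 1 uM; on this read-out lower numbers stand for less inhibition and higher numbers for more inhibition at the one concentration tested (going by the name of the read-out).
Compound 2, `CCCCCc1cc(C(C)=O)c(O)cc1OCCCCC#N`, gives 14% in this assay.
Compound 3, `C=CCc1cc(C(C)=O)c(O)cc1OCCCCCC`, gives 9% in this assay.

The change from compound 1 to compound 2 is methyl in place of hydrogen on a saturated chain carbon, four bonds along the chain from an aromatic carbon; it made a step of a number 1 percentage points higher from compound 1 to compound 2 (within the scatter). Compound 4, `C=CCc1cc(C(C)=O)c(O)cc1OCCCCCCC`, differs from compound 3 by methyl in place of hydrogen on a saturated chain carbon, six bonds along the chain from an oxygen on an aromatic ring. This is the same kind of change as that from compound 1 to compound 2, but the place differs: there the chain carbon is four bonds along the chain from an aromatic carbon, here six bonds along the chain from an oxygen on an aromatic ring. The difference between the cores of compound 1 and compound 3 is not broken down here. All three measured values lie within the scatter of one another. For compound 4 a step of a number 1 percentage points higher from compound 3 to compound 4 (within the scatter) is expected, resting on the step from compound 1 to compound 2 being a number 1 percentage points higher from compound 1 to compound 2 (within the scatter). Compound 4 is therefore estimated at 10%, between 0% and 24%.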

Compound 4, a percentage reported as inhibition, at one concentration (the size of the read-out at that concentration, not a potency): 8%
Beside the measured number, compound 4's estimate is 2 percentage points above it; the measured number falls inside the stated range.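

In this assay, methyl in place of hydrogen on a saturated chain carbon gives a step of a number 1 percentage points lower from compound 3 to compound 4 (within the scatter), and beside the earlier step the change shows no difference between the two cores: the same change on two cores in this assay, a number 1 percentage points higher (within the scatter) from compound 1 to compound 2 and a number 1 percentage points lower (within the scatter) from compound 3 to compound 4, 2 percentage points apart, within the scatter of two such steps

Among the compounds shown here, this shows only that the change leaves no readable step on either core. It does not show that the change has the same effect on both, or any effect at all, and the chain carbon also sits in a different place on each core.

The compounds shown leave open whether a carboxylic acid, an amine or a much longer chain would move the number beyond the scatter in this assay. They also leave open how any such step would carry between these cores.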